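The source may report more compounds than this note shows. Statements on the series, on what has been measured and on what is new or still open speak of the compounds shown alone.

Compound 3 `O=C(Nc1nc2ccc(Cl)cc2s1)c1cn(-c2ccccc2)nc1-c1ccc(F)cc1` gives 3870 nM in a functional assay on A549 cells (Homo sapiens) for cytotoxicity, read by MTT assay, with a stated time of 72 h (a lower number here means a stronger inhibitor, a higher number a weaker inhibitor), the low end of the three numbers shown. Compound 2 `O=C(Nc1nc2ccc(F)cc2s1)c1cn(-c2ccccc2)nc1-c1ccc(F)cc1` gives 6650 nM and compound 1 `O=C(Nc1nc2ccccc2s1)c1cn(-c2ccccc2)nc1-c1ccc(F)cc1` gives 9010 nM in this assay. The step of a 2.3-fold lower number from compound 1 to compound 3 (0.37 log units; beyond the scatter) lies beyond the scatter, whereas a 1.4-fold lower number from compound 1 to compound 2 (0.13 log units; within the scatter) and a 1.7-fold lower number from compound 2 to compound 3 (0.24 log units; within the scatter) lie within it. Compound 4 `COc1ccc2nc(NC(=O)c3cn(-c4ccccc4)nc3-c3ccc(F)cc3)sc2c1` differs from compound 3 by methoxy in place of chloro on an aromatic carbon. Within the data shown here, no measured step involves a methoxy; the steps at the same place, a 2.3-fold lower number from compound 1 to compound 3 (0.37 log units; beyond the scatter) and a 1.4-fold lower number from compound 1 to compound 2 (0.13 log units; within the scatter), were modest or within the scatter, so compound 4 is expected to move little, if at all, beyond the scatter in this assay. The value of compound 4 is estimated at 5500 nM, between 2200 nM and 14000 nM. The expected step is a 1.4-fold higher number from compound 3 to compound 4 (0.15 log units; within the scatter).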

Compound 4, half-maximal inhibitory concentration: > 50000 nM
Compound 4: no number, only a limit; the forecaster's own chance of this, stated with the estimate: 5%; middle value at least 9.0-fold (0.95 log units) away from the limit.
By their numbers in this assay, from the lowest: compounds 3, 2 and 1 (each within the scatter of the next, the first and the last beyond it). At a limit, above all of these: compound 4.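

In this assay compound 4 carries no number, only a limit: the limit of > 50000 nM in this assay, at which 1 of the 4 values shown sits. The earlier steps shown here at this place were small or modest, but this one shows that the place is not indifferent to its substituent: methoxy gives an at least 12-fold higher number from compound 3 to compound 4 (1.11 log units; beyond the scatter), and the same holds against fluoro, with an at least 7.5-fold higher number from compound 2 to compound 4 (0.87 log units; beyond the scatter), and against hydrogen, with an at least 5.5-fold higher number from compound 1 to compound 4 (0.74 log units; beyond the scatter). Unlike chloro, methoxy moves the number upward.

The compounds shown leave open whether a hydroxyl, a methyl or an ethoxy at this place would follow methoxy or chloro. They also leave open whether methoxy elsewhere on the core would have the same effect.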